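Ester chain length on a cyclic urea adenosine ligand

This account rests on a few compounds, and the source may have more. Where it says the series, first, only, none or still open, it means among the compounds named here.

Of the compounds shown here, three sharing one cyclic urea core have been tested in an assay on membranes from HEK293 cells for displacement of a labelled ligand from adenosine receptor A2b (Homo sapiens), read by scintillation counting, with a stated time of 30 min, tested at 1 uM; a lower number here means less inhibition, a higher number more inhibition at the concentration tested (going by the name of the read-out). Compound 1 `COC(=O)C1=C(C)NC(=O)NC1c1ccoc1` gives 42%. Compound 2 `CC1=C(C(=O)OC(C)(C)C)C(c2ccsc2)NC(=O)N1`, which carries a different ester group and a different aromatic ring, gives 47%. Compound 3 `COC(=O)C1=C(C)N(C)C(=O)NC1c1ccco1`, which carries a methyl on a ring nitrogen, gives 31%. Compound 3 therefore stands lowest of the three: the gap to compound 1 and the larger gap to compound 2 both lie beyond the usual scatter of this assay. Since compound 2 differs from compound 3 in more than one place, its higher number cannot be traced to the ester alone.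

The next compound, compound 4 `CCCOC(=O)C1=C(C)N(C)C(=O)NC1c1ccco1`, differs from compound 3 in one place only: ethyl in place of hydrogen on a saturated chain carbon bound to an oxygen next to a carbonyl group. Among the measured compounds shown here, no measured pair here isolates the effect of lengthening the ester chain, so there is no direct precedent on which to rest a prediction. The change is small and adds no donors, acceptors or charge, and the expected step of a number 5 percentage points higher from compound 3 to compound 4 (within the scatter) is accordingly estimated to be small, most likely within the scatter, with at best a slight rise. Compound 4 is thus expected to give about 36%, with a plausible range from 18% to 55%.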

Compound 4, a percentage reported as inhibition, at one concentration (the size of the read-out at that concentration, not a potency): 23%
For compound 4 the middle estimate is 13 percentage points above the measured one; the range from low to high includes it.
By their numbers in this assay, from the lowest: compounds 4 and 3 (each within the scatter of the next); then compounds 1 and 2 (each within the scatter of the next).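

Methoxycarbonyl to propoxycarbonyl is the first change in this series that stands alone, so its effect can be read without a second difference getting in the way, and in this assay it appears as a number 8 percentage points lower from compound 3 to compound 4 (within the scatter). At this position, on the saturated chain carbon bound to an oxygen next to a carbonyl group, ethyl in place of hydrogen therefore gives no difference that can be told from the usual scatter, and this single pair offers no sign that the longer chain brings a gain in inhibition. No independent measurement is available to explain this outcome.

One pair cannot show whether the same small step would appear on a compound without the methyl on the ring nitrogen, or whether a chain much longer than propyl, such as hexyl, would stay within the scatter as well. As far as these compounds go, it also remains open how this position would respond to a group of another kind, such as a benzyl ester, an amide or a carboxylic acid in place of the ester.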